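Swapping cyclopropyl for furan-3-yl on a shared core

The source may report more compounds than this note shows. Statements on the series, on what has been measured and on what is new or still open speak of the compounds shown alone.

In a functional assay on THP-1 cells (Homo sapiens) for inhibition, read by ELISA, with stated times of 1 h and 18 h (on this read-out lower numbers stand for stronger inhibition and higher numbers for weaker inhibition), compound 1 `Cc1cnc(Nc2cccc(C(=O)N3CCCC3)c2)nc1N[C@H]1[C@@H](C(N)=O)[C@@H]2C=C[C@H]1C2` reads 100 nM as its half-maximal inhibitory concentration. Among the compounds with values here, compound 2 `NC(=O)[C@@H]1[C@H](Nc2nc(Nc3cccc(C(=O)N4CCCC4)c3)ncc2C2CC2)[C@H]2C=C[C@@H]1C2` reads 90 nM on the same measure, so the two stand level, within the scatter of each other, and no other measured compound helps to place compound 2 further.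

Compound 3 `NC(=O)[C@@H]1[C@H](Nc2nc(Nc3cccc(C(=O)N4CCCC4)c3)ncc2-c2ccoc2)[C@H]2C=C[C@@H]1C2` is the next step, with furan-3-yl in place of cyclopropyl on an aromatic carbon. Within the data shown here, only one measured step bears on this change: cyclopropyl in place of methyl on the same aromatic carbon, which gave a 1.1-fold lower number from compound 1 to compound 2 (0.05 log units; within the scatter) and so no real shift. Among the measured compounds shown here, that is thin evidence, since no measured compound carries an aromatic ring on that carbon. In this assay no shift beyond the scatter is therefore expected, in either direction. The estimated step is (a 1.1-fold higher number from compound 2 to compound 3 (0.05 log units; within the scatter)). Compound 3 is estimated at 100 nM with an expected range from 35 nM to 300 nM as a deliberately wide margin for a group not yet tried in this series.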

Compound 3, half-maximal inhibitory concentration: 40 nM
Beside the measured number, compound 3's estimate is 2.5-fold (0.40 log units) above it; the measured number falls inside the stated range.
By their numbers in this assay, from the lowest: compound 3; then compounds 2 and 1 (each within the scatter of the next).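

Methyl and cyclopropyl on this aromatic carbon stood level, so the position could have seemed indifferent to what sits there, but in this assay furan-3-yl moves the number beyond the scatter, with a 2.3-fold lower number from compound 2 to compound 3 (0.35 log units; beyond the scatter) and a 2.5-fold lower number from compound 1 to compound 3 (0.40 log units; beyond the scatter). Both steps are modest, yet they show that the group on this carbon, ortho to a large group on the six-membered aromatic ring with 2 nitrogen, can change the read-out, and that an aromatic ring is accepted there without any loss of inhibition. No measurement shown here explains why furan-3-yl gives the lower number.

The change from cyclopropyl alters several things at once, bringing in an aromatic ring, 5 heavy atoms in place of 3 and 1 hydrogen-bond acceptor, so the compounds shown leave open which of these matters. Phenyl would keep an aromatic ring without the oxygen, and tetrahydrofuran-3-yl would keep the oxygen without the aromatic ring, so that each comparison would help to separate these features.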